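Benzyl to 4-methylphenyl: expected cytotoxicity of compound 3

The source may hold more compounds than are shown below. What is called first, only, known or untested is meant among the compounds shown, and "the series" means these compounds.

Measured so far:
compound 1 `Cc1nc(-c2cccnc2)sc1-c1nnc(Cc2ccccc2)o1`: > 100 ug/mL
compound 2 `Cc1nc(-c2cccnc2)sc1-c1nnc(-c2ccc([N+](=O)[O-])cc2)o1`: > 100 ug/mL

In an ADME assay on HCT-116 cells (Homo sapiens) for cytotoxicity, read by MTT assay (on this read-out lower numbers stand for higher toxicity in this test and higher numbers for lower toxicity in this test), compound 1 gives > 100 ug/mL, which is a limit of the assay rather than a number. Compound 2 gives > 100 ug/mL, also a limit. Both values sit at the limit of > 100 ug/mL in this assay, at which 2 of the 2 values shown sit, so compound 1 stands with the other measured compound, not apart from it. Compound 3 `Cc1ccc(-c2nnc(-c3sc(-c4cccnc4)nc3C)o2)cc1` differs from compound 1 in one place: 4-methylphenyl in place of benzyl on an aromatic carbon. Among the measured compounds shown here, no step between measured compounds is available, so no shift beyond the usual scatter is expected from this change; the estimated step is a step that the limit leaves unreadable from compound 1 to compound 3. Compound 3 is therefore expected to give about 120 ug/mL, likely between 50 ug/mL and 300 ug/mL, and most probably again only a limit.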

Compound 3, half-maximal cytotoxic concentration: > 100 ug/mL
Compound 3: a limit, no number; the forecaster's own chance of this, stated with the estimate: 80%; the middle value does not contradict the limit.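

Among the compounds shown here, compound 1, compound 2 and compound 3 each give only a limit in this assay, so no step between them can be read: the limit of > 100 ug/mL in this assay, at which 3 of the 3 values shown sit. The compounds shown leave open whether 4-methylphenyl in place of benzyl changes cytotoxicity at all.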